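Methoxy substitution in a linked carboxyphenyl series

This account rests on a few compounds, and the source may have more. Where it says the series, first, only, none or still open, it means among the compounds named here.

The series shares the core seen in compound 2 `Cc1c(OCCCCOc2ccc(C(=O)O)cc2)ccc(C(=O)CC(C)C)c1O`, which in an assay on HEK293 cells for positive allosteric modulation of metabotropic glutamate receptor 2 (Rattus norvegicus), read by thallium flux, with a stated time of 2.5 min (a lower number here means a smaller maximal response, a higher number a larger maximal response), gives 88%. Compound 1 `COc1cc(C(=O)O)ccc1OCCCCOc1ccc(C(=O)CC(C)C)c(O)c1C` carries methoxy in place of hydrogen on an aromatic carbon and in this assay compound 1 gives 85.7%, a step of a number 2.3 percentage points lower from compound 2 to compound 1 (within the scatter). Compound 3 `Cc1c(OCCCCOc2cccc(C(=O)O)c2)ccc(C(=O)CC(C)C)c1O` differs from compound 2 in its core by 3-carboxyphenyl in place of 4-carboxyphenyl on an oxygen on a saturated carbon; in this assay compound 3 gives 84.5%, a step of a number 3.5 percentage points lower from compound 2 to compound 3 (within the scatter). Compound 4 `COc1ccc(C(=O)O)cc1OCCCCOc1ccc(C(=O)CC(C)C)c(O)c1C`, not yet measured, differs from compound 3 by methoxy in place of hydrogen on an aromatic carbon. Among the measured compounds shown here, this is the same kind of change as the one giving compound 1, though the place differs: there the methoxy is meta to a carboxy group, here it is para to a carboxy group. The step from compound 3 to compound 4 in this assay is expected to be a number 1.5 percentage points lower from compound 3 to compound 4 (within the scatter), resting on the size of a number 2.3 percentage points lower from compound 2 to compound 1 (within the scatter). Compound 4 is estimated at 83%, between 73% and 93%.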

Compound 4, largest response reached (reported as percent of maximum), in percent of the reference or control that the assay uses: 89.7%
The estimate for compound 4 lay 6.7 percentage points below the measured number, and the stated range covers the measured number.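

In this assay, methoxy in place of hydrogen on an aromatic carbon gives a step of a number 5.2 percentage points higher from compound 3 to compound 4 (within the scatter), so on this core, as on the core of compound 2, the change leaves the maximal response within the usual scatter. The two steps carry opposite signs, but the gap between them cannot be read as a difference between the cores: the same change on two cores in this assay, a number 2.3 percentage points lower (within the scatter) from compound 2 to compound 1 and a number 5.2 percentage points higher (within the scatter) from compound 3 to compound 4, 7.5 percentage points apart, within the scatter of two such steps

This supports carrying the change between these two cores with no readable shift in response, but two steps do not show whether the place of the methoxy matters or establish a rule for the series.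

The compounds shown leave open whether the response holds when the carboxylic acid is replaced by an amide or a tetrazole, or when the linking chain is shorter or longer. They also leave open whether ethoxy on the same aromatic carbon gives a step beyond the scatter.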